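This account rests on a few compounds, and the source may have more. Where it says the series, first, only, none or still open, it means among the compounds named here.

Compound 3 `COc1cc2ncnc(Nc3cccc(C(F)(F)F)c3)c2cc1OCCCSc1nc2ccccc2o1` gives 4030 nM in a functional assay on MCF7 cells (Homo sapiens) for cytotoxicity, read by MTT assay, with a stated time of 24 h; a lower number here means a stronger inhibitor, a higher number a weaker inhibitor. Compound 1 `COc1cc2ncnc(Nc3cccc(C(F)(F)F)c3)c2cc1OCCCSc1nc2ccccc2s1` gives 4050 nM in this assay, and compound 2 `COc1cc2ncnc(Nc3ccc(F)c(Cl)c3)c2cc1OCCCSc1nc2ccccc2o1` gives 4050 nM; compound 3 thus sits level with both, as the steps of a 1.0-fold lower number from compound 1 to compound 3 (0.00 log units; within the scatter) and a 1.0-fold lower number from compound 2 to compound 3 (0.00 log units; within the scatter) show. Compound 4 `COc1cc2ncnc(Nc3ccc(OC(F)(F)F)cc3)c2cc1OCCCSc1nc2ccccc2o1` differs from compound 3 by 4-(trifluoromethoxy)phenyl in place of 3-(trifluoromethyl)phenyl on a nitrogen on an aromatic ring. Within the data shown here, no measured step exchanges exactly these two groups. The closest comparison, a 1.0-fold lower number from compound 2 to compound 3 (0.00 log units; within the scatter), swaps one aryl group on that same nitrogen for another and stays within the scatter, and the exchange on the sulfur, a 1.0-fold lower number from compound 1 to compound 3 (0.00 log units; within the scatter), is likewise flat. For compound 4 a step of a 1.0-fold lower number from compound 3 to compound 4 (0.00 log units; within the scatter) is therefore expected, nothing beyond the scatter. Compound 4 is accordingly estimated at 4000 nM, within a range of 2000 nM to 8000 nM.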

Compound 4, half-maximal inhibitory concentration: 9080 nM
Compound 4: the middle estimate sits 2.3-fold (0.36 log units) below what was measured; measured number outside the range, above it.
By their numbers in this assay, from the lowest: compounds 3, 1 and 2 (each within the scatter of the next); then compound 4.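

In this assay the aryl group on a nitrogen on an aromatic ring now registers: 4-(trifluoromethoxy)phenyl gives a 2.3-fold higher number from compound 3 to compound 4 (0.35 log units; beyond the scatter) and a 2.2-fold higher number from compound 2 to compound 4 (0.35 log units; beyond the scatter), both modest and both toward a higher number. The earlier exchange at this nitrogen stayed within the scatter, so this position is not insensitive to every aryl change. No measured evidence bears on why this exchange registers.

Open, as far as these compounds go, is whether the step persists alongside 1,3-benzothiazol-2-yl on the sulfur. Also open, from the compounds shown here alone, is how an aryl group carrying an amine or a carboxylic acid would read here.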